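The compounds below may be only part of what the source reports. "The series", "measured", "known", "first", "only" and "open" are said of these compounds alone.

In a functional assay on T47D cells (Homo sapiens) for inhibition, read by CCK-8 assay, with a stated time of 72 h, tested at 1 uM (on this read-out lower numbers stand for less inhibition of growth and higher numbers for more inhibition of growth at the one concentration tested), compound 3 (`CN(C)C(=O)c1cc2cnc(Nc3ccc(NC(=O)C4(C(=O)Nc5cccc(Cl)c5)CC4)cc3)nc2n1C1CCCC1`) gives 39.3% and sits at the low end of this small set, with compound 2 (`Cc1cccc(NC(=O)C2(C(=O)Nc3ccc(Nc4ncc5cc(C(=O)N(C)C)n(C6CCCC6)c5n4)cc3)CC2)c1`) at 45.7% within the scatter of it. Compound 1 (`CN(C)C(=O)c1cc2cnc(Nc3ccc(NC(=O)C4(C(=O)Nc5ccc(F)cc5)CC4)cc3)nc2n1C1CCCC1`) stands clear of both at 74.7% on the same read-out.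

Next comes compound 4 (`CN(C)C(=O)c1cc2cnc(Nc3ccc(NC(=O)C4(C(=O)Nc5ccc(Br)cc5)CC4)cc3)nc2n1C1CCCC1`), in which 4-bromophenyl takes the place of 3-chlorophenyl on an amide-type nitrogen. The counted change is 4-bromophenyl in place of 3-chlorophenyl on an amide-type nitrogen and the rest of the structure stays the same.

Among the measured compounds shown here, three measured steps bear on this. Moving away from the 4-fluorophenyl group of compound 1 gives a number 29 percentage points lower from compound 1 to compound 2 (beyond the scatter) and also a number 35.4 percentage points lower from compound 1 to compound 3 (beyond the scatter) and both lie beyond the scatter. The exchange of methyl for chloro gives a number 6.4 percentage points lower from compound 2 to compound 3 (within the scatter) and stays within the scatter. The entering 4-bromophenyl is closer by name to the group on compound 1 than to those on compound 2 and compound 3. For the measured compounds named here, that reading rests on compound 1 alone, and no bromine compound has been measured.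

Recovery of part of the gap is therefore expected, not all of it. The expected change is a number 20.7 percentage points higher from compound 3 to compound 4 (beyond the scatter) in the upward direction, a step of moderate size. For compound 4 the estimate is 60% with an expected range from 40% to 78% in this assay.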

Compound 4, percent growth inhibition at one concentration: 21.1%
Compound 4: middle estimate off by 38.9 percentage points, on the high side, and the stated range ends above it.
By their numbers in this assay, from the lowest: compound 4; then compounds 3 and 2 (each within the scatter of the next); then compound 1.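

In this assay, 4-bromophenyl in place of 3-chlorophenyl gives a number 18.2 percentage points lower from compound 3 to compound 4 (beyond the scatter) and, in place of 3-methylphenyl, gives a number 24.6 percentage points lower from compound 2 to compound 4 (beyond the scatter) as its second reading, so a group named at the 4-position of the phenyl ring does not by itself keep the number high on this amide-type nitrogen. Bromo in place of fluoro on the same aromatic carbon gives a number 53.6 percentage points lower from compound 1 to compound 4 (beyond the scatter) and is the largest step in the series so far, which ties the high number of compound 1 to 4-fluorophenyl specifically, with compound 4 going against any reading based on ring position alone. The data at hand give no reason why fluoro and bromo part so widely here.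

The compounds shown leave open whether 4-chlorophenyl or 4-methylphenyl would sit nearer compound 1 or compound 4, and whether 3-fluorophenyl would keep any of the number that 4-fluorophenyl carries. Also open, as far as these compounds go, is how an unsubstituted phenyl, a 4-methoxyphenyl or a phenyl bearing an amine or a carboxylic acid would read at this position.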